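Dimethylamino in Place of Acetyl on the Outer Ring

The source may hold more compounds than are shown below. What is called first, only, known or untested is meant among the compounds shown, and "the series" means these compounds.

Compound 1 `COc1cc(C)cc(-c2c(-c3ccnc(-c4ccc(C(C)=O)cc4)c3)cnn2CC#N)c1` and compound 2 `COc1cc(C)cc(-c2nn(CC#N)cc2-c2ccc(-c3cccc(C(C)=O)c3)nc2)c1` share a common core and were both tested in a functional assay on OVCAR-4 cells (Homo sapiens) for cytotoxicity, read by sulforhodamine B assay, with a stated time of 48 h, tested at 1 uM; on this read-out higher numbers stand for a weaker effect at the one concentration tested and lower numbers for a stronger effect. In this assay compound 1 gives 27%, the higher of the two numbers recorded so far. Compound 2 gives 19% in this assay, a value that lies within the usual scatter of the number for compound 1, so the two cannot be put in order. Compound 3 `COc1cc(C)cc(-c2c(-c3ccnc(-c4ccc(N(C)C)cc4)c3)cnn2CC#N)c1` has not yet been measured. It differs from compound 1 in one place: dimethylamino in place of acetyl on an aromatic carbon. For the measured compounds named here, no step between measured compounds touches this part of the structure, so the size of the change in this assay must be judged without a precedent. Resting only on the numbers already shown, the step expected is a number 3 percentage points higher from compound 1 to compound 3 (within the scatter), a change not beyond the scatter. For compound 3 the expected value is 30%, ranging from 10% to 55%.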

Compound 3, a percentage reported as activity, at one concentration (the size of the read-out at that concentration, not a potency): 31%
Compound 3: the middle estimate sits 1 percentage points below what was measured; low and high end bracket the measured number.
By their numbers in this assay, from the lowest: compounds 2, 1 and 3 (each within the scatter of the next, the first and the last beyond it).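

In this assay, for the compounds shown here, the exchange of 4-acetylphenyl for 4-(dimethylamino)phenyl gives a number 4 percentage points higher from compound 1 to compound 3 (within the scatter), the first reading of a single change at this position, on an aromatic carbon para to a large group. Acetyl and dimethylamino therefore cannot be told apart here at the one concentration tested, even though the carbonyl double bond leaves and a nitrogen enters while the heavy-atom and hydrogen-bond acceptor counts stay the same. No measurement available bears on why the two groups read alike.

From the compounds shown here alone, whether a carboxylic acid, a primary amine or a longer alkyl chain at this position would read differently from acetyl and dimethylamino remains open. So does whether the two groups would stay indistinguishable at other concentrations, which a single-concentration read-out cannot show.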